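Replacing a phenolic hydroxy with methoxy on an oxindole-derived scaffold

The source may hold more compounds than are shown below. What is called first, only, known or untested is meant among the compounds shown, and "the series" means these compounds.

Compound 1 `COc1cc2c(/C=C3/C(=O)Nc4ccc(O)cc43)c(Cl)n(Cc3cc(OC)c(OC)c(OC)c3)c2cc1C` was tested in a functional assay on cells (Cancer cell lines, Homo sapiens) for cytotoxicity, with a stated time of 48 h (a lower number here means a stronger inhibitor of growth, a higher number a weaker inhibitor of growth), where compound 1 gives 2340 nM. Two other compounds share this measurement. Compound 2 `COc1cc2c(/C=C3/C(=O)Nc4cccc(Cl)c43)c(Cl)n(Cc3cc(OC)c(OC)c(OC)c3)c2cc1C` gives 3980 nM in this assay, and compound 3 `COc1c(/C=C2/C(=O)Nc3ccccc32)c2ccccc2n1-c1ccccc1` gives 1380 nM. Among these three numbers compound 1 holds the second highest, yet each of the three values lies within the scatter of the others, so no ordering among them can be read from the data.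

Compound 4 `COc1ccc2c(c1)/C(=C\c1c(Cl)n(Cc3cc(OC)c(OC)c(OC)c3)c3cc(C)c(OC)cc13)C(=O)N2` differs from compound 1 in one place: methyl in place of hydrogen on an oxygen on an aromatic ring. Within the data shown here, no measured pair shows exactly this change. Among the measured compounds shown here, the only step that touches the same part of the structure is a 1.7-fold higher number from compound 1 to compound 2 (0.23 log units; within the scatter), in which the ring bearing the hydroxy was exchanged for one bearing a chlorine instead; that exchange moved the number only within the scatter. The remaining pair, compound 1 and compound 3, shows two values within the scatter of each other and involves several changes at once.

On this basis the step from compound 1 to compound 4 is expected to stay within the scatter, a 1.1-fold higher number from compound 1 to compound 4 (0.03 log units; within the scatter). Compound 4 is therefore estimated at 2500 nM in this assay, with a range from 1000 nM to 6500 nM.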

Compound 4, concentration for 50% growth inhibition: 33100 nM
Beside the measured number, compound 4's estimate is 13-fold (1.12 log units) below it; the measured number lies above the stated range.
By their numbers in this assay, from the lowest: compounds 3, 1 and 2 (each within the scatter of the next, the first and the last beyond it); then compound 4.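

In this assay methyl in place of hydrogen on an oxygen on an aromatic ring gives a 14-fold higher number from compound 1 to compound 4 (1.15 log units; beyond the scatter) and so marks this oxygen as a place where one added carbon is enough to weaken growth inhibition, the only step among these compounds to pass beyond the scatter. The earlier step in the same part of the structure gave no warning of this: a 1.7-fold higher number from compound 1 to compound 2 (0.23 log units; within the scatter) also removes the hydroxy, with a chlorine entering the ring, so among the compounds shown the absence of the hydroxy does not by itself go with a large rise, while hydroxy to methoxy does. No measurement given here accounts for the size of this step.

As far as these compounds go, the finding rests on a single pair in a single assay, so it remains open whether the same change would act alike on the core of compound 3. Also open, from the compounds shown here alone, is how an ethoxy, an amine or a fluorine in this place would compare with the hydroxy and the methoxy.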